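This account rests on a few compounds, and the source may have more. Where it says the series, first, only, none or still open, it means among the compounds named here.

Compound 1 `C/N=C(/NC#N)NCCCCCCn1nc(-c2ccccc2)ccc1=O`: in a functional assay on the whole organism (stomach) with Rattus norvegicus as the target (a lower number here means that less compound is needed, a higher number that more compound is needed for the effect), compound 1 gives > 100 mg/kg, which is a limit of the assay, not a number.
Compound 2 `CC/N=C(/NC#N)NCCCCCn1nc(-c2ccccc2)ccc1=O`: in this assay compound 2 gives 100 mg/kg.
Compound 3 `C/N=C(\S)NCCCCn1nc(C)ccc1=O`: in this assay compound 3 gives > 100 mg/kg, again a limit of the assay rather than a number.

Compound 3 thus stands at a limit, and the limit of > 100 mg/kg in this assay, at which 2 of the 3 values shown sit, shows that most of the values seen so far sit there. Going by the values given here, the one measured step, a number no higher from compound 1 to compound 2 (the limit leaves the size open), swaps one chain-bound group for another on a saturated chain carbon and leaves the size of the step open; it does not touch the position changed here. The change to compound 4 `C/N=C(/NC#N)NCCCCn1nc(C)ccc1=O` is a group of 6 heavy atoms (3 carbon, 3 nitrogen; no ring) in place of a group of 4 heavy atoms (2 carbon, 1 nitrogen, 1 sulfur; no ring), on an amine nitrogen. The entering group is the same one carried by compound 2, and in this assay compound 2 gives 100 mg/kg. Among the compounds with values here, no measured step bears directly on this change, and nothing beyond the scatter is expected; the expected step is a number no higher from compound 3 to compound 4 (the limit leaves the size open). Compound 4 is expected to give 100 mg/kg, with a range from 40 mg/kg to 300 mg/kg, and a limit rather than a number remains quite possible.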

Compound 4, dose for half-maximal effect: > 100 mg/kg
Compound 4: a limit, no number; the forecaster's own chance of this, stated with the estimate: 55%; the middle value lies on the limit itself.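

Compound 3 and compound 4 both stand at a limit, not at a number, so no step between them can be read: the limit of > 100 mg/kg in this assay, at which 3 of the 4 values shown sit.

The compounds shown leave open whether the change of group on the amine nitrogen alters the dose needed, and by how much.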